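From Acetyl to Nitrophenyl Carbonyl: A Projected Step

The source may hold more compounds than are shown below. What is called first, only, known or untested is meant among the compounds shown, and "the series" means these compounds.

Two measured compounds frame this step. In an assay on isolated protein for inhibition of Rho-associated protein kinase 2 (Homo sapiens), read by scintillation counting, radiometric assay and 33P incorporation, with a stated time of 40 min, in the presence of a further agent that is not named here (on this read-out lower numbers stand for stronger inhibition and higher numbers for weaker inhibition), compound 1 `Cc1coc2cc(OCC(=O)Nc3cccc(NC(=O)c4ccc(N(C)C)cc4)c3)ccc2c1=O` gives 2150 nM, while compound 2 `CC(=O)Nc1cccc(NC(=O)COc2ccc3c(=O)ccoc3c2)c1` gives 136 nM, the lowest of the two numbers, and the gap between them lies well beyond the usual scatter. Compound 3 `O=C(COc1ccc2c(=O)ccoc2c1)Nc1cccc(NC(=O)c2ccc([N+](=O)[O-])cc2)c1` has not yet been measured in this assay. It differs from compound 2 in one place: 4-nitrophenyl in place of methyl on a carbonyl carbon. Cut one bond further out, the change reads acetyl to (4-nitrophenyl)carbonyl. Among the measured compounds shown here, no pair of measured compounds isolates this change, and compound 1 differs from compound 2 in more than one place, so its higher number cannot be tied to the aryl carbonyl alone. The author nonetheless expects the step of a 3.7-fold higher number from compound 2 to compound 3 (0.57 log units; beyond the scatter) to be a loss, moderate in size and probably beyond the scatter. Compound 3 is therefore estimated at 500 nM, with a range from 150 nM to 2500 nM.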

Compound 3, half-maximal inhibitory concentration: 15 nM
For compound 3 the middle estimate is 33-fold (1.52 log units) above the measured one; the measured number lies below the stated range.
By their numbers in this assay, from the lowest: compound 3; then compound 2; then compound 1.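

In this assay, 4-nitrophenyl in place of methyl on a carbonyl carbon bonded to an amide-type nitrogen gives a 9.1-fold lower number from compound 2 to compound 3 (0.96 log units; beyond the scatter), so this position accepts the aryl group with a gain rather than a loss. An aryl carbonyl here is therefore compatible with a low number, which compound 1 could not show, as it differs from compound 2 in more than one place. Nothing measured here explains why the number falls.

The compounds shown do not separate the contribution of the phenyl ring from that of the nitro group, a question that an unsubstituted phenyl, or a phenyl carrying an amine or a carboxylic acid instead of the nitro group, would address. They also leave open how much of the higher number of compound 1 belongs to its dimethylamino group and how much to the extra methyl on its core.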